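Cyclopropyl for propyl on an aminophenyl pyrazoline core

This account rests on a few compounds, and the source may have more. Where it says the series, first, only, none or still open, it means among the compounds named here.

Measured compounds:
compound 1 `CCCC(=O)N1CCC(c2cc(OC)ccc2N)=N1` with 13.1%
compound 2 `COc1ccc(N)c(C2=NN(C(=O)C3CC3)CC2)c1` with 19.9%
compound 3 `CCCC(=O)N1CCC(c2ccccc2N)=N1` with 0.35%

Three compounds were tested in an assay on isolated protein for inhibition of Nitric oxide synthase, inducible (Homo sapiens), with a stated time of 30 min, tested at 1 mM; a lower number here means less inhibition, a higher number more inhibition at the concentration tested (going by the name of the read-out). Compound 1 gives 13.1% in this assay. Compound 2, which carries cyclopropyl in place of propyl on a carbonyl carbon, gives 19.9%; the step of a number 6.8 percentage points higher from compound 1 to compound 2 (within the scatter) lies within the scatter. Compound 3 differs from compound 1 by hydrogen in place of methoxy on an aromatic carbon; in this assay compound 3 gives 0.35%, the lowest of the three numbers, and the step of a number 12.8 percentage points lower from compound 1 to compound 3 (beyond the scatter) is beyond the scatter.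

Compound 4 `Nc1ccccc1C1=NN(C(=O)C2CC2)CC1` is not yet measured. It differs from compound 3 by cyclopropyl in place of propyl on a carbonyl carbon, the same change that separates compound 1 from compound 2, made on the core of compound 3 rather than that of compound 1. That earlier step was within the scatter, so the step is expected to be small here too; the expected step of a number 4.7 percentage points higher from compound 3 to compound 4 (within the scatter) rests on the earlier step of a number 6.8 percentage points higher from compound 1 to compound 2 (within the scatter) and on the value of compound 3, 0.35%. Compound 4 is estimated to give 5% in this assay, expected between 0% and 17%.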

Compound 4, a percentage reported as inhibition, at one concentration (the size of the read-out at that concentration, not a potency): 14.8%
Compound 4: the middle estimate sits 9.8 percentage points below what was measured; the range from low to high includes it.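

In this assay, cyclopropyl in place of propyl on a carbonyl carbon gives a number 14.5 percentage points higher from compound 3 to compound 4 (beyond the scatter), and the two steps for this change on the two cores cannot be told apart: the same change on two cores in this assay, a number 6.8 percentage points higher (within the scatter) from compound 1 to compound 2 and a number 14.5 percentage points higher (beyond the scatter) from compound 3 to compound 4, 7.7 percentage points apart, within the scatter of two such steps. Hydrogen in place of methoxy on an aromatic carbon gives a number 5.1 percentage points lower from compound 2 to compound 4 (within the scatter), and this change likewise carries from one core to the other without a difference that can be told apart: the same change on two cores in this assay, a number 12.8 percentage points lower (beyond the scatter) from compound 1 to compound 3 and a number 5.1 percentage points lower (within the scatter) from compound 2 to compound 4, 7.7 percentage points apart, within the scatter of two such steps. This shows that both changes point the same way on the two cores shown, but with only two pairs for each change, and with readings taken at a single concentration rather than potencies, it does not show that the size of either step is fixed or that either would hold on another core.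

The compounds shown leave open how a cyclobutyl ring or a longer chain would read in place of cyclopropyl on the carbonyl carbon. They also leave open what a fluorine or a hydroxyl would do in place of methoxy on the aromatic carbon.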